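Shrinking the Amide Side Chain of a Glutamate Receptor Modulator

The source may report more compounds than this note shows. Statements on the series, on what has been measured and on what is new or still open speak of the compounds shown alone.

Compound 1, `O=C(C1CCC2(CCC2)CC1)N1CC(c2nc(-c3cccc(Cl)c3)no2)C1`: 1100 nM in an assay on HEK293 cells for positive allosteric modulation of metabotropic glutamate receptor 5 (Homo sapiens), read by FLIPR; on this read-out lower numbers stand for an effect already at smaller amounts and higher numbers for an effect only at larger amounts of compound
Compound 2, `Cc1ccc(S(=O)(=O)N2CC(c3nc(-c4cccc(Cl)c4)no3)C2)cc1`: > 10000 nM
Compound 3, `O=C(c1ccc(Cl)cc1)N1CC(c2nc(-c3cccc(F)c3)no2)C1`: 2500 nM

Of the two numbers given, compound 1 stands at the lower one; compound 3 gives a higher number, and that gap lies beyond the usual scatter. For compound 2 the result is only a limit of the assay, not a number (the limit of > 10000 nM in this assay, at which 1 of the 3 values shown sits). Compound 4, `CC1CCCC(C(=O)N2CC(c3nc(-c4cccc(Cl)c4)no3)C2)C1`, has not yet been measured in this assay. It differs from compound 1 at one place: a group of 7 heavy atoms (7 carbon; one six-membered non-aromatic ring of carbon only) in place of a group of 9 heavy atoms (9 carbon; one four-membered non-aromatic ring of carbon only, one six-membered non-aromatic ring of carbon only), on a carbonyl carbon. Among the compounds with values here, no measured pair shows a step of this kind, so the expectation rests on compound 1 alone. A small rise in the number, or none beyond the scatter, is expected: compound 4 is estimated at 1800 nM, with a range from 700 nM to 5000 nM. That estimate means an expected step of a 1.6-fold higher number from compound 1 to compound 4 (0.21 log units; within the scatter).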

Compound 4, half-maximal effective concentration: 410 nM
Beside the measured number, compound 4's estimate is 4.4-fold (0.64 log units) above it; the measured number lies below the stated range.
By their numbers in this assay, from the lowest: compound 4; then compound 1; then compound 3. At a limit, above all of these: compound 2.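

In this assay, within the data shown here, putting 3-methylcyclohexyl on the carbonyl carbon gives a 2.7-fold lower number from compound 1 to compound 4 (0.43 log units; beyond the scatter), a step that no earlier pair could show. At this position, then, the four-membered ring of compound 1 is not needed for the effect, and a smaller group made only of carbon gives a lower number. The compounds shown offer no measurement that explains this gain.

Whether the methyl group itself contributes remains open, since plain cyclohexyl is not among these compounds. So does the outcome of placing an amine or a hydroxyl group on this ring.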